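Methyl on the amine nitrogen across two cores

A few compounds are considered here, and "the series" means these few. Any claim that something is new, unique, unknown or untested is made for them only; others in the source may bear on it.

Measured in a functional assay on MCF7 cells (Homo sapiens) for antiproliferative activity, read by MTT assay, with a stated time of 48 h (on this read-out higher numbers stand for weaker inhibition and lower numbers for stronger inhibition), so far:
compound 1 `CNCC(=O)Nc1cc(OC)ccc1C(=O)c1ccc2c(c1)C=CC(C)(C)O2` gives 1210 nM
compound 2 `COc1ccc(C(=O)c2ccc3c(c2)C=CC(C)(C)O3)c(NC(=O)CN(C)C)c1` gives 3560 nM
compound 3 `C=C(c1ccc(OC)cc1NC(=O)CN)c1ccc(OC)c2c1OC(C)(C)C=C2` gives 220 nM

Compound 1 and compound 2 share one core; compound 3 stands on another, and the difference between the two cores is not broken down here. Compound 3 has the lowest number of the three, and its gaps to compound 1 and to compound 2 both lie beyond the scatter.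

Among the compounds with values here, the single change with a measured step is methyl in place of hydrogen on an amine nitrogen, and it gave a 2.9-fold higher number from compound 1 to compound 2 (0.47 log units; beyond the scatter).

Compound 4 `C=C(c1ccc(OC)cc1NC(=O)CNC)c1ccc(OC)c2c1OC(C)(C)C=C2` is not yet measured in this assay. It arises from compound 3 by methyl in place of hydrogen on an amine nitrogen. This is the same kind of change as that from compound 1 to compound 2, not the same: in compound 1 the amine nitrogen's other neighbours are saturated chain carbon, saturated chain carbon, whereas in compound 3 its other neighbour is a single saturated chain carbon, so the methyl enters on a nitrogen that carried none before.

Within the data shown here, the expected step for compound 4 is a 2.0-fold higher number from compound 3 to compound 4 (0.31 log units; beyond the scatter), resting on one measured instance of the kind, because of a 2.9-fold higher number from compound 1 to compound 2 (0.47 log units; beyond the scatter) weakening being the only precedent. Compound 4 is therefore estimated at 450 nM, with a range from 180 nM to 1200 nM.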

Compound 4, half-maximal inhibitory concentration: 400 nM
Estimate against measurement, compound 4: 1.1-fold (0.05 log units) above; measured number inside the range.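

In this assay, methyl in place of hydrogen on an amine nitrogen gives a 1.8-fold higher number from compound 3 to compound 4 (0.26 log units; within the scatter), so this pair is not separated by the read-out. The two instances of the change, on two cores, cannot be told apart: the same change on two cores in this assay, a 2.9-fold higher number (0.47 log units; beyond the scatter) from compound 1 to compound 2 and a 1.8-fold higher number (0.26 log units; within the scatter) from compound 3 to compound 4, 1.6-fold (0.21 log units) apart, within the scatter of two such steps. Within the data shown here, this is compatible with the change carrying over from one core to the other, but two steps establish no rule for the series, only the step on the core of compound 1 lies beyond the scatter, and the two steps are not identical, as the methyl joins a nitrogen already bearing one in compound 1 and a nitrogen bearing none in compound 3.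

The compounds shown leave open how the dimethylamino group behaves on the core of compound 3 and how the free amino group behaves on the core of compound 1, either of which would give each core a fuller series on the same nitrogen. Also open, as far as these compounds go, is whether a larger group there, such as ethyl, follows the same course as methyl.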